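The source may hold more compounds than are shown below. What is called first, only, known or untested is meant among the compounds shown, and "the series" means these compounds.

In a functional assay on T-24 cells (Homo sapiens) for antiproliferative activity, read by MTT assay, with a stated time of 48 h (a lower number here means a stronger inhibitor, a higher number a weaker inhibitor), compound 1 `O=C(Nc1ccccc1)Nc1cccc(CNc2nccnc2Cl)c1` gives 19800 nM, and compound 2 `COc1ccc(NC(=O)Nc2cccc(CNc3nccnc3Cl)c2)cc1` gives 9820 nM. Adding the methoxy group produces a 2.0-fold lower number from compound 1 to compound 2 (0.30 log units; within the scatter), so these two values cannot be told apart. Compound 3 `O=C(Nc1cccc(CNc2nccnc2Cl)c1)NC1CCCC1` reaches only a limit of the assay, > 40000 nM. Exchanging the whole 4-methoxyphenyl for cyclopentyl gives an at least 4.0-fold higher number from compound 2 to compound 3 (0.60 log units; beyond the scatter), while the exchange of phenyl for cyclopentyl gives an at least 2.0-fold higher number from compound 1 to compound 3 (0.30 log units; that floor lies within the scatter). Compound 2 therefore stands level with compound 1 and clear of compound 3.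

Compound 4 `O=C(Nc1ccc(C(F)(F)F)cc1)Nc1cccc(CNc2nccnc2Cl)c1` is still unmeasured. Its difference is trifluoromethyl in place of methoxy on an aromatic carbon, with the aromatic ring itself kept. Going by the values given here, the closest precedent is the hydrogen-to-methoxy change, which gave a 2.0-fold lower number from compound 1 to compound 2 (0.30 log units; within the scatter), whereas the larger shift came from losing the aromatic ring, as in an at least 4.0-fold higher number from compound 2 to compound 3 (0.60 log units; beyond the scatter). No step beyond the scatter is therefore expected in this assay, and no firm direction can be predicted. The expected result is a 1.2-fold lower number from compound 2 to compound 4 (0.09 log units; within the scatter). For compound 4 the estimated value is 8000 nM, with an expected range of 3000 nM to 22000 nM.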

Compound 4, half-maximal inhibitory concentration: 4580 nM
For compound 4 the middle estimate is 1.7-fold (0.24 log units) above the measured one; the measured number falls inside the stated range.
By their numbers in this assay, from the lowest: compound 4; then compounds 2 and 1 (each within the scatter of the next). At a limit, above all of these: compound 3.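

In this assay, trifluoromethyl in place of methoxy gives a 2.1-fold lower number from compound 2 to compound 4 (0.33 log units; beyond the scatter), and trifluoromethyl in place of hydrogen at the same position gives a 4.3-fold lower number from compound 1 to compound 4 (0.64 log units; beyond the scatter). Going by these compounds alone, the one earlier change at this position, hydrogen to methoxy, stayed within the scatter, so these modest steps are the first to show that the group held here can shift the number while the aromatic ring stays in place. Nothing measured here accounts for the difference between these groups.

Going by these compounds, with only hydrogen, methoxy and trifluoromethyl at this position, it remains open how a chlorine atom, a nitrile, an amine or a carboxylic acid would compare there. On these data alone, it is also open whether a longer chain at this position would keep the lower number of compound 4.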